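Carboxyethyl on the ring nitrogen of compound 2

The source may report more compounds than this note shows. Statements on the series, on what has been measured and on what is new or still open speak of the compounds shown alone.

In an assay on 32D cells for inhibition of interleukin-15 (Mus musculus), read by resazurin assay, with stated times of 30 min and 2.5 days, in the presence of a further agent that is not named here (on this read-out lower numbers stand for stronger inhibition and higher numbers for weaker inhibition), compound 2 `Cn1nc(Cc2nnc(SCCCCCCCC(=O)Nc3ccc(Cl)cc3Cl)[nH]2)c2ccccc2c1=O` gives 1100 nM, the only numeric result in the set. Compound 1 `CCOC(CCn1c(Cc2nn(C)c(=O)c3ccccc23)nnc1SCC(=O)Nc1ccc(Cl)cc1Cl)OCC` returns only the assay limit, > 30000 nM. Compound 3 `Cn1nc(Cc2nnc(SCC(=O)Nc3ccc(Cl)cc3Cl)n2CCCO)c2ccccc2c1=O` likewise stops at the limit, > 30000 nM. The step that the two limits leave unreadable from compound 1 to compound 3 therefore cannot be read, since both ends sit at the limit of > 30000 nM in this assay, at which 2 of the 3 values shown sit. Compound 4 `Cn1nc(Cc2nnc(SCCCCCCCC(=O)Nc3ccc(Cl)cc3Cl)n2CCC(=O)O)c2ccccc2c1=O` differs from compound 2 by 2-carboxyethyl in place of hydrogen on an aromatic nitrogen. For the measured compounds named here, no measured step covers this change; compound 1 and compound 3, which both carry a group on that ring nitrogen, return no number, but they also differ from compound 2 in the chain, so they point a direction only loosely. A loss is expected for compound 4, estimated at 5000 nM (range 1500 nM to 30000 nM). The expected step is a 4.5-fold higher number from compound 2 to compound 4 (0.66 log units; beyond the scatter).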

Compound 4, half-maximal inhibitory concentration: 23500 nM
Estimate against measurement, compound 4: 4.7-fold (0.67 log units) below; the range from low to high includes it.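

With the long chain held fixed, the aromatic nitrogen now gives a readable change: in this assay, 2-carboxyethyl in place of hydrogen gives a 21-fold higher number from compound 2 to compound 4 (1.33 log units; beyond the scatter). This is a large loss from a single substitution at this position, yet compound 4 still returns a number and not the assay limit. Nothing measured here accounts for the loss.

As far as these compounds go, it remains open whether the loss follows the carboxylic acid itself or any group on that nitrogen. A methyl group, an ethyl ester or an amine there would separate these readings.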